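This account rests on a few compounds, and the source may have more. Where it says the series, first, only, none or still open, it means among the compounds named here.

Measured so far in a functional assay on MCF7 cells (Homo sapiens) for inhibition, read by MTT assay, with a stated time of 72 h; a lower number here means a stronger inhibitor of growth, a higher number a weaker inhibitor of growth:

compound 1 `CC(C)(C)c1ccc(CNCCCNS(=O)(=O)c2cc(C(F)(F)F)cc(C(F)(F)F)c2)cc1` — 2100 nM
compound 2 `O=S(=O)(NCCCNCc1ccc(Cl)c(Cl)c1)c1cc(C(F)(F)F)cc(C(F)(F)F)c1` — 2400 nM
compound 3 `COc1ccc(CNCCCNS(=O)(=O)c2cc(C(F)(F)F)cc(C(F)(F)F)c2)cc1OC` — 1900 nM

Compound 3 gives the lowest of the three numbers in this assay, but its gaps to compound 1 and compound 2 are within the scatter, so the three cannot be ordered. The shared core, a bis(trifluoromethyl)benzenesulfonamide on a three-carbon chain to a secondary amine, is constant; only the aryl group on the saturated chain carbon bound to the amine nitrogen varies.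

Compound 4 `O=S(=O)(NCCCNCC1COc2ccccc2O1)c1cc(C(F)(F)F)cc(C(F)(F)F)c1` differs from compound 3 by 2,3-dihydro-1,4-benzodioxin-2-yl in place of 3,4-dimethoxyphenyl on a saturated chain carbon bound to an amine nitrogen.

Among the measured compounds shown here, the steps that bear on this are the aryl exchanges already measured: a 1.1-fold higher number from compound 1 to compound 2 (0.06 log units; within the scatter), a 1.1-fold lower number from compound 1 to compound 3 (0.04 log units; within the scatter) and a 1.3-fold lower number from compound 2 to compound 3 (0.10 log units; within the scatter). None left the scatter, so this position has so far tolerated substituent changes without a shift in this assay. For the measured compounds named here, the change to compound 4 is of a different kind, since the two oxygens now close a non-aromatic ring, and no measured step tests that directly. On the evidence at hand, compound 4 is expected to show a 1.2-fold higher number from compound 3 to compound 4 (0.08 log units; within the scatter), with a somewhat wider band to allow for the untested ring closure. The estimate for compound 4 is 2300 nM, within 1000 nM to 5500 nM.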

Compound 4, concentration for 50% growth inhibition: 2500 nM
Estimate against measurement, compound 4: 1.1-fold (0.04 log units) below; low and high end bracket the measured number.
By their numbers in this assay, from the lowest: compounds 3, 1, 2 and 4 (each within the scatter of the next).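

In this assay, 2,3-dihydro-1,4-benzodioxin-2-yl brings a six-membered non-aromatic ring with 2 hetero atoms to this place, yet the steps read a 1.3-fold higher number from compound 3 to compound 4 (0.12 log units; within the scatter) and a 1.0-fold higher number from compound 2 to compound 4 (0.02 log units; within the scatter) and also a 1.2-fold higher number from compound 1 to compound 4 (0.08 log units; within the scatter) (all within the scatter). The tolerance seen among the three substituted phenyl groups therefore extends to this ring-closed group, and across the four compounds no exchange on the saturated chain carbon bound to an amine nitrogen has left the scatter. No measurement at hand accounts for this flat result.

From the compounds shown here alone, what remains open is whether any group at this place can move the number beyond the scatter, for example a carboxylic acid or a primary amine on the aromatic ring. The shared core is also untested here: a longer chain, or a replacement for the trifluoromethyl groups, could matter more than the exchanges seen so far.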